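From 4-fluorobenzyl to isobutyl on a shared core

A few compounds are considered here, and "the series" means these few. Any claim that something is new, unique, unknown or untested is made for them only; others in the source may bear on it.

Measured so far in a physicochemical assay for solubility, with a stated time of 18 h, at pH 7.4; on this read-out higher numbers stand for higher solubility and lower numbers for lower solubility:
compound 1 `COc1ccc(-c2ccc3c(NCCCNCc4cccc(OC)c4O)ccnc3c2)cc1`: 32000 nM
compound 2 `COc1cccc(CNCCCNc2ccnc3cc(Cc4cc(C)cc(C)c4)ccc23)c1O`: 4200 nM
compound 3 `COc1cccc(CNCCCNc2ccnc3cc(Cc4ccc(F)cc4)ccc23)c1O`: 4200 nM

Compound 3 shares its number with compound 2, and together they hold the lowest of the three values, well under compound 1. The next compound, compound 4 `COc1cccc(CNCCCNc2ccnc3cc(CC(C)C)ccc23)c1O`, departs from compound 3 by one change: isopropyl in place of 4-fluorophenyl on a saturated chain carbon bound to an aromatic carbon. In words, isopropyl takes the place of 4-fluorophenyl on a saturated chain carbon bound to an aromatic carbon, which, cut one bond further out, reads 4-fluorobenzyl to isobutyl.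

Going by the values given here, three measured steps bear on this. The only one at the same place is no change at the digits printed from compound 2 to compound 3 (within the scatter), but it exchanges one aromatic ring for another. Among the compounds with values here, the change to compound 4 removes the ring altogether, and no measured compound shows that. The two larger steps, a 7.6-fold lower number from compound 1 to compound 2 (0.88 log units; beyond the scatter) and a 7.6-fold lower number from compound 1 to compound 3 (0.88 log units; beyond the scatter), mark the size a change of this group has reached so far. A modest rise in this assay is therefore expected, though the direction is tentative and the step should not exceed those two in size. The expected size is a 2.4-fold higher number from compound 3 to compound 4 (0.38 log units; beyond the scatter). For compound 4 the estimate is 10000 nM, with an expected range from 3500 nM to 30000 nM.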

Compound 4, solubility: 4200 nM
Estimate against measurement, compound 4: 2.4-fold (0.38 log units) above; the measured number falls inside the stated range.
By their numbers in this assay, from the lowest: compounds 2, 3 and 4 (each within the scatter of the next); then compound 1.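

In this assay, going by these compounds alone, the earlier compounds had only exchanged one aromatic ring for another at this place, whereas compound 4 has no ring there, and the change to isopropyl still gives no change at the digits printed from compound 3 to compound 4 (within the scatter) and, against the 3,5-dimethylphenyl group, no change at the digits printed from compound 2 to compound 4 (within the scatter) in the same read-out. Among these compounds, then, the ring on the saturated chain carbon is not needed for the number to stay where it is, and a group of 3 heavy atoms sits level with one of 7 heavy atoms. The gap to compound 1 also survives the loss of the ring, with a 7.6-fold lower number from compound 1 to compound 4 (0.88 log units; beyond the scatter) matching in size the two steps seen before, so all three compounds that carry a saturated chain carbon at this place stand apart from compound 1, which has 4-methoxyphenyl on the aromatic carbon. Nothing available accounts for this flat result.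

The compounds shown leave open whether an amine or a carboxylic acid on this saturated chain carbon would move the number, since every group seen there so far is a hydrocarbon or a fluorinated aromatic ring. They also leave open which part of the 4-methoxyphenyl of compound 1 goes with its higher number, as a phenyl without the methoxy group on the same aromatic carbon is not among them.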